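Vero cytotoxicity across the shared core: towards compound 3

The source may report more compounds than this note shows. Statements on the series, on what has been measured and on what is new or still open speak of the compounds shown alone.

Compound 1 `CN1Cc2ccc(OCCCn3cnc([N+](=O)[O-])c3)cc2[C@@H](O)C1`: in an ADME assay on Vero cells (Chlorocebus sabaeus) for cytotoxicity, read by sulforhodamine B assay, with a stated time of 72 h (on this read-out lower numbers stand for stronger inhibition and higher numbers for weaker inhibition), compound 1 gives > 50000 nM, a limit of the assay.
Compound 2 `CN1Cc2ccc(OCc3ccc(Oc4ccc(F)cc4)cc3)cc2[C@@H](O)C1`: in this assay compound 2 gives 5600 nM.

Compound 2 holds the only number shown; the other value sits at the limit of > 50000 nM in this assay, at which 1 of the 2 values shown sits. Going by the values given here, no pair of measured compounds differs in one place, so no measured step size is available. Compound 3 `CN1Cc2ccc(OCc3ccc(-c4ccc5ccccc5c4)cc3)cc2[C@@H](O)C1` differs from compound 2 by naphthalen-2-yl in place of 4-fluorophenoxy on an aromatic carbon. The expected change in this assay is small, within the scatter or a modest move towards stronger inhibition, an estimated 1.2-fold lower number from compound 2 to compound 3 (0.09 log units; within the scatter). Compound 3 is therefore estimated at 4500 nM, within 1500 nM to 20000 nM.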

Compound 3, half-maximal inhibitory concentration: 310 nM
Compound 3: the middle estimate sits 15-fold (1.16 log units) above what was measured; the whole stated range lies above it.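

In this assay, going by these compounds alone, the aromatic carbon para to a large group proves sensitive to what it carries: naphthalen-2-yl in place of 4-fluorophenoxy gives an 18-fold lower number from compound 2 to compound 3 (1.26 log units; beyond the scatter), the first measured step. This single pair shows that the position can shift this read-out well beyond the scatter. Nothing shown gives a cause for the step.

As far as these compounds go, whether the step follows the second fused ring, the loss of the ether oxygen or the loss of the fluorine stays open. From the compounds shown here alone, how an unsubstituted phenyl or a pyridine at this carbon would read also stays open.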